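A few compounds are considered here, and "the series" means these few. Any claim that something is new, unique, unknown or untested is made for them only; others in the source may bear on it.

Measured in a functional assay on HT-29 cells (Homo sapiens) for cytotoxicity, read by sulforhodamine B assay, with a stated time of 72 h; a higher number here means a weaker inhibitor of growth, a lower number a stronger inhibitor of growth:
- compound 1 `C=C1CC[C@@H]2[C@](C)(CCC[C@]2(C)C(=O)OC)[C@H]1CCc1ccc2c(OCc3ccccc3)ccc(OCc3ccccc3)c2c1`: > 5000 nM (a limit)
- compound 2 `C=C1[C@H](O)C[C@@H]2[C@](C)(CCC[C@]2(C)C(=O)OC)[C@H]1CCc1ccc2c(OCc3ccccc3)ccc(OCc3ccccc3)c2c1`: > 4900 nM (a limit)

Neither measured compound has a numerical value in this assay. Compound 1 stands only at a limit, > 5000 nM, and this gives it no exact place in the series. Compound 2 is likewise reported only as a limit, > 4900 nM.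

Compound 3 `C=C1CC[C@@H]2[C@](C)(CCC[C@]2(C)C(=O)OC)[C@]1(O)CCc1ccc2c(OCc3ccccc3)ccc(OCc3ccccc3)c2c1` has not yet been measured. It differs from compound 1 by one change: hydroxy in place of hydrogen on a saturated ring carbon. Going by the values given here, the one measured step that bears on it is the same kind of change, hydroxy in place of hydrogen on a saturated ring carbon. That step is a step that the two limits leave unreadable from compound 1 to compound 2, so it gives no size and no direction. Among the compounds with values here, it shows only that compound 2 also failed to give a number. With nothing measured to suggest a shift, no step beyond the usual scatter is expected, and a further limit is the likeliest report. The estimated step is a number no higher from compound 1 to compound 3 (the limit leaves the size open). Compound 3 is estimated at 5000 nM, with an expected range of 2000 nM to 10000 nM.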

Compound 3, concentration for 50% growth inhibition: 12400 nM
The estimate for compound 3 lay 2.5-fold (0.39 log units) below the measured number; the whole stated range lies below it.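

In this assay, going by these compounds alone, compound 3 gives a number while compound 1 stands only at a limit, and no step between compound 1 and compound 3 can be read. The compounds shown leave open whether hydroxy in place of hydrogen on a saturated ring carbon shifts growth inhibition at all.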